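Pyridin-4-yl amide replacing dichlorophenyl on the cyclopentyloxy benzamide core

The compounds below may be only part of what the source reports. "The series", "measured", "known", "first", "only" and "open" are said of these compounds alone.

Working notes on the series, read in an assay on isolated protein for inhibition of phosphodiesterase 4A (Sus scrofa); a higher number here means a weaker inhibitor, a lower number a stronger inhibitor. Compound 1 `COc1ccc(C(=O)Nc2cccc(Cl)c2Cl)cc1OC1CCCC1` gives > 200000 nM, which is a limit of the assay and not a number. Compound 1 therefore stands at the limit of > 200000 nM in this assay, at which 1 of the 2 values shown sits, and cannot be placed on the numbers more closely than that. Compound 2 `O=C(Nc1c(F)cccc1F)c1cccc(OC2CCCC2)c1` carries a different core and gives 15000 nM in this assay, a measured number. For the measured compounds named here, no measured step within this set exists.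

Compound 3 `COc1ccc(C(=O)Nc2ccncc2)cc1OC1CCCC1` differs from compound 1 in one place: pyridin-4-yl in place of 2,3-dichlorophenyl on an amide-type nitrogen. As a change on an amide-type nitrogen whose other neighbours are the carbonyl carbon, the step from compound 1 to compound 3 in this assay is expected to be large and toward stronger inhibition, an at least 66-fold lower number from compound 1 to compound 3 (1.82 log units; beyond the scatter). Compound 3 is expected to give an estimated 3000 nM in this assay, with a range of 300 nM to 30000 nM.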

Compound 3, half-maximal inhibitory concentration: 800 nM
For compound 3 the middle estimate is 3.8-fold (0.57 log units) above the measured one; the range from low to high includes it.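

The change from 2,3-dichlorophenyl to pyridin-4-yl on the amide-type nitrogen gives, in this assay, an at least 250-fold lower number from compound 1 to compound 3 (2.39 log units; beyond the scatter). For the compounds shown here, this is the first readable step in the set, and it shows that a change in this one place is enough to take the shared core from a limit of the assay to a measured number. The value of compound 1 is a limit, and the true size of the step therefore remains open: the limit of > 200000 nM in this assay, at which 1 of the 3 values shown sits.

The change removes both chlorines and brings in a ring nitrogen together, and a plain phenyl or a pyridin-3-yl on the same nitrogen would be needed to separate the two. Going by these compounds alone, no step to compound 2 can be read, and the effect of replacing the cyclopentyloxy group with a smaller ether such as ethoxy is also open.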